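Bromo in place of chloro on compound 3

The source may report more compounds than this note shows. Statements on the series, on what has been measured and on what is new or still open speak of the compounds shown alone.

In a functional assay on HEK293 cells (Homo sapiens) for cytotoxicity (on this read-out lower numbers stand for higher toxicity in this test and higher numbers for lower toxicity in this test), compound 1 (`COc1ccc([C@H]2CC(=O)N(c3cccc(O)c3)C2)cc1OC1CCCC1`) gives > 10000 nM as a limit. Compound 2 (`COc1ccc([C@H]2CC(=O)N(c3cccc(C)c3)C2)cc1OC1CCCC1`) gives > 10000 nM as a limit. Compound 3 (`COc1ccc([C@H]2CC(=O)N(c3cccc(NS(=O)(=O)c4cccc(Cl)c4)c3)C2)cc1OC1CCCC1`) gives > 10000 nM as a limit. Going by the values given here, the series so far therefore reads only as one shared ceiling (the limit of > 10000 nM in this assay, at which 3 of the 3 values shown sit). Compound 4 (`COc1ccc([C@H]2CC(=O)N(c3cccc(NS(=O)(=O)c4cccc(Br)c4)c3)C2)cc1OC1CCCC1`) differs from compound 3 by one exchange (bromo in place of chloro on an aromatic carbon), bromo in place of chloro on an aromatic carbon. The measured steps that bear on it are a step that the two limits leave unreadable from compound 1 to compound 3 and a step that the two limits leave unreadable from compound 2 to compound 3 and neither gives a size to carry over. With compound 3 held at the limit (> 10000 nM) no step beyond the scatter is expected in this assay and no direction can be assigned. The estimated step is a step that the limit leaves unreadable from compound 3 to compound 4 as a nominal figure. For compound 4 the expected value is 15000 nM with 8000 nM to 30000 nM as the estimated range.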

Compound 4, half-maximal cytotoxic concentration: > 10000 nM
Compound 4 was reported as a limit; the forecaster's own chance of this, stated with the estimate: 90%; the middle value lies beyond the limit too.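

In this assay, going by these compounds alone, compound 4 gives > 10000 nM as a limit, so no step among compound 1, compound 2, compound 3 and compound 4 can be read: the limit of > 10000 nM in this assay, at which 4 of the 4 values shown sit.

As far as these compounds go, whether these four compounds differ at all in this assay stays open.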